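The compounds below may be only part of what the source reports. "The series", "measured", "known", "first", "only" and "open" are said of these compounds alone.

Series notes, metabolic stability in an ADME assay on microsomes from liver (Homo sapiens) for metabolic stability, read by LC-MS, using NADPH, tested at 5 uM; a lower number here means that the compound disappears faster, a higher number that the compound lasts longer:

- compound 1 `Cc1cc(S(=O)(=O)/N=C(\N)n2nccc2-c2ccccc2)c(SCc2cccc(Cl)c2)cc1Cl`: 0.309 h
- compound 2 `Cc1cc(S(=O)(=O)/N=C(\N)n2nccc2-c2ccccc2)c(SCc2ccccc2)cc1Cl`: 0.0772 h
- compound 3 `Cc1cc(-c2ccccc2)n(/C(N)=N/S(=O)(=O)c2cc(C)c(Cl)cc2SCc2ccc(Cl)cc2)n1`: 0.24 h

Compound 3 sits second highest of the three numbers in this assay. Its number is within the scatter of that of compound 1, and compound 2 lies beyond the scatter below it. Compounds 1 and 3 differ in more than one place, so only their two numbers can be set side by side.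

Compound 4 `Cc1cc(S(=O)(=O)/N=C(\N)n2nccc2-c2ccccc2)c(SCc2ccc(Cl)cc2)cc1Cl` is not yet measured. Relative to compound 3 the change is hydrogen in place of methyl on an aromatic carbon of the five-membered aromatic ring with 2 nitrogen.

Among the measured compounds shown here, the one single-point step measured so far, a 4.0-fold lower number from compound 1 to compound 2 (0.60 log units; beyond the scatter), concerns a chloro on the benzyl ring and not the methyl on the five-membered ring, so no measured step bears directly on the change from compound 3 to compound 4. Without a comparable step, the expectation is a step of about no change at the digits printed from compound 3 to compound 4 (within the scatter) in this assay, not beyond the scatter in either direction.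

Compound 4 is therefore estimated at 0.24 h in this assay, with a range from 0.09 h to 0.6 h.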

Compound 4, half-life: 0.34 h
Compound 4: the middle estimate sits 1.4-fold (0.15 log units) below what was measured, within the range that was stated.
By their numbers in this assay, from the lowest: compound 2; then compounds 3, 1 and 4 (each within the scatter of the next).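

In this assay, among the compounds shown here, hydrogen in place of methyl on an aromatic carbon of the five-membered aromatic ring with 2 nitrogen gives a 1.4-fold higher number from compound 3 to compound 4 (0.15 log units; within the scatter) and so leaves the half-life within the scatter in this one pair, the first measured step at this position. The chloro change now has a second reading: chloro in place of hydrogen on an aromatic carbon gives a 4.4-fold higher number from compound 2 to compound 4 (0.64 log units; beyond the scatter) in the same direction as the earlier comparison, while 4-chlorophenyl in place of 3-chlorophenyl gives a 1.1-fold higher number from compound 1 to compound 4 (0.04 log units; within the scatter) and separates the two chlorinated compounds by no more than the scatter. Nothing measured here accounts for any of these steps.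

The compounds shown leave open whether an ethyl group, an amine or a carboxylic acid on that aromatic carbon of the five-membered ring would keep the half-life in this assay where it stands in this pair. For the compounds shown here, they also leave open whether hydrogen in place of methyl reads the same way with 3-chlorophenyl or unsubstituted phenyl at the other end of the molecule, since the single pair carries 4-chlorophenyl.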